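A few compounds are considered here, and "the series" means these few. Any claim that something is new, unique, unknown or untested is made for them only; others in the source may bear on it.

Compound 1 `COc1ccc(Cc2coc3cc(OC)cc(OC)c3c2=O)cc1` was examined in a functional assay on H9c2 cells (Mus musculus) for cytotoxicity against H9c2 (Rattus norvegicus), read by MTT assay, with a stated time of 24 h; on this read-out lower numbers stand for an effect already at smaller amounts and higher numbers for an effect only at larger amounts of compound. In this assay compound 1 gives only a limit of the assay, > 100000 nM, and no number, so its standing on the numbers shown is a limit alone. Compound 2 `COc1cc(OC)c2c(=O)c(Cc3ccc(C(F)(F)F)cc3)coc2c1` differs from compound 1 by a trifluoromethyl in place of a methoxy on an aromatic carbon. In this assay compound 2 likewise reaches only a limit, > 100000 nM. The step that the two limits leave unreadable from compound 1 to compound 2 therefore cannot be read, since both of its ends sit at the limit of > 100000 nM in this assay, at which 2 of the 2 values shown sit. Compound 3 `COc1cc(OC)c2c(=O)c(Cc3ccc(Cl)c(Cl)c3)coc2c1` has not yet been measured in this assay. Its change from compound 1 is 3,4-dichlorophenyl in place of 4-methoxyphenyl on a saturated chain carbon bound to an aromatic carbon. For the measured compounds named here, only one measured step exists and it is unreadable; the two measured values merely show that neither compound reached a number. No direction of change can be drawn from that. For compound 3 the expected step is a step that the limit leaves unreadable from compound 1 to compound 3, which means most likely another limit. Compound 3 is estimated at 150000 nM, between 50000 nM and 500000 nM, with a limit the more probable outcome.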

Compound 3, half-maximal effective concentration: 23800 nM
Beside the measured number, compound 3's estimate is 6.3-fold (0.80 log units) above it; measured number below the stated range.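

In this assay, for the compounds shown here, 3,4-dichlorophenyl in place of 4-methoxyphenyl on a saturated chain carbon bound to an aromatic carbon gives an at least 4.2-fold lower number from compound 1 to compound 3 (0.62 log units; beyond the scatter), the first step that can be read. A lower number means that damage to the cells appears at smaller amounts of compound, so the group at this position can shift the result away from the limit of the assay while the shared core stays the same. This remains a single readable step, as the other steps cannot be read and most of the series still rests on a limit: the limit of > 100000 nM in this assay, at which 2 of the 3 values shown sit.

The change swaps a whole substituted ring, so these compounds cannot separate the contribution of each chlorine from the loss of the methoxy, and a ring with only one chlorine would be needed to begin that comparison. Going by these compounds, it also remains open how the result would respond to an amine or a carboxylic acid on that ring, or to a longer chain in place of the single saturated chain carbon.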